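A dihydroxyphenyl swap on the shared core

The source may report more compounds than this note shows. Statements on the series, on what has been measured and on what is new or still open speak of the compounds shown alone.

- compound 1 `CCC1=C(O)c2c(oc(-c3ccc(CBr)cc3)cc2=O)C(CC)(CC)C1=O` gives > 46.5 uM as a limit
- compound 2 `CCC1=C(O)c2c(oc(-c3ccc(OC)c(C)c3)cc2=O)C(CC)(CC)C1=O` gives 28.5 uM as a number

Going by the values given here, in a functional assay on KB cells (Homo sapiens) for antiproliferative activity, read by sulforhodamine B assay, with a stated time of 3 days (a lower number here means that less compound is needed, a higher number that more compound is needed for the effect), compound 2 with 28.5 uM is the only compound so far with a true number. For compound 1 the value > 46.5 uM is a limit of the assay and not a number. Among the compounds with values here, the one measured step is an at least 1.6-fold lower number from compound 1 to compound 2 (0.21 log units; that floor lies within the scatter) and it offers only weak guidance. Compound 3 `CCC1=C(O)c2c(oc(-c3ccc(O)c(O)c3)cc2=O)C(CC)(CC)C1=O` differs from compound 2 as follows 3,4-dihydroxyphenyl in place of 4-methoxy-3-methylphenyl on an aromatic carbon and so carries 3,4-dihydroxyphenyl in place of 4-methoxy-3-methylphenyl on an aromatic carbon. Within the data shown here, no measured step covers this swap, so no shift beyond the scatter is expected in this assay in either direction. The expected change is only a 1.1-fold lower number from compound 2 to compound 3 (0.06 log units; within the scatter) and nothing larger. A result reported only as a limit, as for compound 1, remains possible. The estimate for compound 3 is 25 uM (from 9 uM to 54 uM).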

Compound 3, concentration for half-maximal effect: 10 uM
Estimate against measurement, compound 3: 2.5-fold (0.40 log units) above, and the stated range covers the measured number.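

The earlier step at this position had a floor within the scatter, whereas in this assay 3,4-dihydroxyphenyl in place of 4-methoxy-3-methylphenyl gives a 2.9-fold lower number from compound 2 to compound 3 (0.45 log units; beyond the scatter), so the group on this aromatic carbon can move the number. Set against 4-(bromomethyl)phenyl, the same group gives an at least 4.6-fold lower number from compound 1 to compound 3 (0.66 log units; beyond the scatter). That step is only a floor, as the reading for compound 1 is a limit and not a number: the limit of > 46.5 uM in this assay, at which 1 of the 3 values shown sits.

The step from compound 2 swaps the methoxy and the methyl groups together, so the compounds shown cannot tell which of the two changes carries the shift. They also leave open how a phenyl ring bearing a single hydroxyl, an amine or a carboxylic acid would read in this assay.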